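This account rests on a few compounds, and the source may have more. Where it says the series, first, only, none or still open, it means among the compounds named here.

Measured so far:
- Compound 1, `C=CCn1c(=O)n(C2C=CC(CO)O2)c2nc(N)nc(O)c21`, gives 6 uM in a functional assay (B cells) with Mus musculus as the target; a higher number here means that more compound is needed for the effect, a lower number that less compound is needed.
- Compound 2, `COc1ccc(Cn2c(=O)n(C3OC(CO)[C@@H](O)[C@H]3O)c3nc(N)nc(O)c32)cc1`, gives 135 uM in this assay.
- Compound 3, `CCCn1c(=O)n(C2OC(COP(=O)(O)O)[C@@H](O)[C@H]2O)c2nc(N)nc(O)c21`, gives 15 uM in this assay.

Of these three numbers, compound 2 stands highest: it needs the most compound for the half-maximal effect, and its gap to compound 3 and to compound 1 lies beyond the usual scatter. The two compounds that need less carry short, open chains on the aromatic nitrogen of the shared core, while compound 2 carries an aromatic ring there.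

Compound 4, `[N-]=[N+]=NCC(O)Cn1c(=O)n(C2OC(CO)[C@@H](O)[C@H]2O)c2nc(N)nc(O)c21`, has not yet been measured. It differs from compound 2 in one place: 2-azido-1-hydroxyethyl in place of 4-methoxyphenyl on a saturated chain carbon bound to an aromatic nitrogen. The group that enters has no ring and is smaller than the group that leaves, which brings compound 4 closer in shape to compound 1 and compound 3 at that position.

A step toward a lower number is therefore expected, of moderate size, a 5.4-fold lower number from compound 2 to compound 4 (0.73 log units; beyond the scatter), because compound 3 with a short open chain gives 15 uM. For compound 4 the estimate is 25 uM, within a range from 6 uM to 100 uM.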

Compound 4, concentration for half-maximal effect: 39 uM
The estimate for compound 4 lay 1.6-fold (0.19 log units) below the measured number, within the range that was stated.
By their numbers in this assay, from the lowest: compound 1; then compound 3; then compound 4; then compound 2.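

For the compounds shown here, compound 1 and compound 3 differ from compound 2 in more than one place, so compound 4 gives the first clean reading of this position. With everything else unchanged, exchanging 4-methoxybenzyl for 3-azido-2-hydroxypropyl gives a 3.5-fold lower number from compound 2 to compound 4 (0.54 log units; beyond the scatter) in this assay. The number therefore responds to the group at this position, and in this pair the group without an aromatic ring gives the lower number.

No measurement shown here explains this step. Going by these compounds, the exchange removes the ring and brings in the azido and hydroxyl groups all at once, so their shares remain open; a plain benzyl group, or a chain ending in an amine in place of the azido group, on the same core would help separate them.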